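The source may hold more compounds than are shown below. What is called first, only, known or untested is meant among the compounds shown, and "the series" means these compounds.

In an ADME assay on Hepa-1c1c7 cells (Mus musculus) for cytotoxicity (a higher number here means a weaker inhibitor, a lower number a stronger inhibitor), compound 1 (`CCCCCCCCCC(O)C#CC#C[C@@H](O)[C@H](C)O`) gives 39800 nM. Compound 2 (`CCCCCC(O)C#CC#C[C@@H](O)[C@H](C)O`) stands at > 500000 nM, which is a limit of the assay and not a number. Compound 3 (`CCCCCCC(O)C#CC#C[C@@H](O)[C@H](C)O`) differs from compound 2 by methyl in place of hydrogen on a saturated chain carbon, six bonds along the chain from an oxygen on a saturated carbon and a triple-bonded carbon, with methyl in place of hydrogen on a saturated chain carbon. Going by the values given here, the only measured step at this place has butyl leaving for hydrogen, an at least 12-fold higher number from compound 1 to compound 2 (1.09 log units; beyond the scatter). Methyl is the smallest part of that butyl, so only a fraction of that step is expected in this assay, towards a lower number. The expected step is an at least 1.6-fold lower number from compound 2 to compound 3 (0.22 log units; that floor lies within the scatter). Compound 3 is estimated at 300000 nM, with an expected range of 130000 nM to 600000 nM.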

Compound 3, half-maximal inhibitory concentration: 223000 nM
Estimate against measurement, compound 3: 1.3-fold (0.13 log units) above; the range from low to high includes it.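

In this assay, methyl alone at this place already gives an at least 2.2-fold lower number from compound 2 to compound 3 (0.35 log units; beyond the scatter), so even the smallest addition to the chain moves the number beyond the scatter. Methyl does not carry the whole of the butyl step, however: the propyl further out still accounts for a 5.6-fold higher number from compound 1 to compound 3 (0.75 log units; beyond the scatter). Compound 2 is a limit of the assay and not a number, so the methyl step is only a floor: the limit of > 500000 nM in this assay, at which 1 of the 3 values shown sits.

Going by these compounds alone, whether a chain longer than the one in compound 1 lowers the number further remains open. So does the effect of an amine or a carboxylic acid on this chain.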